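The compounds below may be only part of what the source reports. "The series", "measured", "known", "first", "only" and "open" are said of these compounds alone.

Measured in a functional assay on CHO-K1 cells for antagonist activity at adenosine receptor A1 (Homo sapiens), read by a beta-galactosidase reporter and cAMP accumulation, with stated times of 15 min and 6 h; a lower number here means a stronger inhibitor, a higher number a weaker inhibitor:
Compound 1 `Cc1ccc(-c2nc(N)c3cc(Cc4ccccc4F)sc3n2)o1`: < 16 nM, a limit of this assay.
Compound 2 `CC(C)c1ccc(-c2nc(N)c3cc(Cc4ccccc4)sc3n2)o1`: 283 nM.
Compound 3 `Cc1csc(-c2nc(N)c3cc(C4(c5ccccc5)CC4)sc3n2)n1`: > 610 nM, a limit of this assay.

Among these three, compound 2 gives the only actual number; the other two results are limits, the limit of < 16 nM in this assay, at which 1 of the 3 values shown sits, and (the limit of > 610 nM in this assay, at which 1 of the 3 values shown sits). Compound 4 `Nc1nc(-c2ccccc2)nc2sc(Cc3ccccc3)cc12` has not yet been measured. It differs from compound 2 in one place: phenyl in place of 5-isopropylfuran-2-yl on an aromatic carbon. For the measured compounds named here, no two measured compounds differ in a single place, so no measured step guides this change. In this assay a modest move towards a lower number is expected for compound 4, one that may not go beyond the usual scatter. Compound 4 is therefore estimated at 150 nM, within a range of 30 nM to 800 nM, an expected step of a 1.9-fold lower number from compound 2 to compound 4 (0.28 log units; within the scatter).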

Compound 4, inhibition constant: 151 nM
The estimate for compound 4 lay 1.0-fold (0.00 log units) below the measured number, within the range that was stated.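

In this assay, putting phenyl in place of 5-isopropylfuran-2-yl on the aromatic carbon between two ring nitrogen atoms gives a 1.9-fold lower number from compound 2 to compound 4 (0.27 log units; within the scatter) and so leaves the inhibitor's strength within the usual scatter. This first single-place comparison shows that this position accepts a carbon-only phenyl ring as well as the oxygen-containing furan ring carrying an isopropyl group. No measurement shown here bears on why these two compounds match. Still open, from the compounds shown here alone, is how a phenyl ring carrying an amine or a carboxylic acid would fare at this position, and whether a longer alkyl chain would be accepted there too.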